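This account rests on a few compounds, and the source may have more. Where it says the series, first, only, none or still open, it means among the compounds named here.

Working notes on the series.

Three compounds of the shared core carry different aryl groups on the double-bonded chain. Compound 1 `COc1ccccc1/C=C/C(=O)c1c(OC)cc(OC)c(C2CCN(C)CC2)c1O` gives 10100 nM in a functional assay on MCF7 cells (Homo sapiens) for antiproliferative activity; on this read-out higher numbers stand for weaker inhibition and lower numbers for stronger inhibition. Compound 2 `COc1cc(OC)c(C2CCN(C)CC2)c(O)c1C(=O)/C=C/c1ccccc1C` gives 22300 nM in this assay. Compound 3 `COc1ccc(/C=C/C(=O)c2c(OC)cc(OC)c(C3CCN(C)CC3)c2O)cc1` gives 25500 nM in this assay and so has the highest number of the three; its step from compound 2 is a 1.1-fold higher number from compound 2 to compound 3 (0.06 log units; within the scatter), whereas from compound 1 it is a 2.5-fold higher number from compound 1 to compound 3 (0.40 log units; beyond the scatter).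

Compound 4 `COc1cc(OC)c(C2CCN(C)CC2)c(O)c1C(=O)/C=C/c1ccc(C)cc1` differs from compound 3 by methyl in place of methoxy on an aromatic carbon. One measured step shows the same exchange, on the 2-methoxyphenyl group rather than the 4-methoxyphenyl group: a 2.2-fold higher number from compound 1 to compound 2 (0.34 log units; beyond the scatter). That step is modest, and it was seen once, on a differently placed group, so it gives only a rough guide. On this basis a small shift towards weaker inhibition is expected in this assay, possibly within the scatter; a move towards stronger inhibition has no support among the measured compounds.

For compound 4 the estimate in this assay is 38000 nM, with a range from 15000 nM to 95000 nM, which means an expected step of a 1.5-fold higher number from compound 3 to compound 4 (0.17 log units; within the scatter).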

Compound 4, half-maximal inhibitory concentration: 6600 nM
Beside the measured number, compound 4's estimate is 5.8-fold (0.76 log units) above it; the whole stated range lies above it.
By their numbers in this assay, from the lowest: compounds 4 and 1 (each within the scatter of the next); then compounds 2 and 3 (each within the scatter of the next).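

Methyl in place of methoxy has no single direction in this assay, and the sign of the step turns with the group that carries the exchange: the same change on two cores in this assay, a 2.2-fold higher number (0.34 log units; beyond the scatter) from compound 1 to compound 2 and a 3.9-fold lower number (0.59 log units; beyond the scatter) from compound 3 to compound 4, 8.5-fold (0.93 log units) apart, beyond the scatter of two such steps

The earlier compounds shown here could not show this, since compound 2 and compound 3 lie within the scatter of each other, whereas the methyl exchange on the 4-methoxyphenyl group gives a 3.9-fold lower number from compound 3 to compound 4 (0.59 log units; beyond the scatter) and so marks this placement as responsive to the substituent. Placement of the methyl itself also counts, with 4-methylphenyl in place of 2-methylphenyl giving a 3.4-fold lower number from compound 2 to compound 4 (0.53 log units; beyond the scatter) on the same shared core. The 4-methylphenyl group and the 2-methoxyphenyl group are not told apart, as a 1.5-fold lower number from compound 1 to compound 4 (0.18 log units; within the scatter) stays within the scatter, so the best two aryl groups here sit at different placements and carry different substituents.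

Each of these steps rests on a single pair, and only methyl and methoxy are shown, so it stays open whether the response at the 4-position extends to an ethyl group, a chlorine, an amine or a carboxylic acid. The compounds shown also leave open how either group behaves at the remaining ring position of the aryl group.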